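Removing a hydroxy from a weakly active isoflavone core

A few compounds are considered here, and "the series" means these few. Any claim that something is new, unique, unknown or untested is made for them only; others in the source may bear on it.

Compound 1 `COc1ccc(-c2coc3cc(OCC=C(C)C)cc(O)c3c2=O)cc1OC`: > 50000 nM
Compound 2 `COc1cc(O)c2c(=O)c(-c3cc(OC)c(O)c(O)c3CC=C(C)C)coc2c1`: 16500 nM
Compound 3 `COc1cc(-c2coc3cc(O)cc(O)c3c2=O)ccc1O`: > 50000 nM

Of the compounds shown here, three share a core and have been tested in a functional assay on BV-2 cells (Mus musculus) for inhibition; on this read-out lower numbers stand for stronger inhibition and higher numbers for weaker inhibition. Compound 1 gives only a limit, > 50000 nM, not a number. Compound 3 likewise gives only a limit, > 50000 nM. Compound 2, with its prenyl chain on the other ring, gives a number, 16500 nM, and is the only one of the three to do so. Two of the three values therefore sit at the limit of > 50000 nM in this assay, at which 2 of the 3 values shown sit, and compound 1 stands at that limit rather than at a measured point.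

Compound 4 `COc1ccc(-c2coc3cc(OCC=C(C)C)ccc3c2=O)cc1OC` differs from compound 1 in one place: hydrogen in place of hydroxy on an aromatic carbon. No measured pair shows a change of this kind, so its size cannot be read from the data shown. Compound 1 starts at a limit, so a step in this assay can only be recognised if compound 4 gains enough to register a number; a loss would stay hidden. Compound 4 is expected to remain weak, most likely again at the limit, with an estimated step that the limit leaves unreadable from compound 1 to compound 4. Compound 4 is estimated at 60000 nM, within 15000 nM to 250000 nM.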

Compound 4, half-maximal inhibitory concentration: 36900 nM
Estimate against measurement, compound 4: 1.6-fold (0.21 log units) above; the measured number falls inside the stated range.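

With the hydroxy on the aromatic carbon ortho to a fused ring replaced by hydrogen, the read-out in this assay shows an at least 1.3-fold lower number from compound 1 to compound 4 (0.13 log units; that floor lies within the scatter). Going by these compounds alone, this is the first sign that this hydroxy is not needed for a measurable value on this core, at least with the (3-methylbut-2-en-1-yl)oxy group in place. The step is only a floor, and its true size cannot be read, since compound 1 stands at a limit and not at a number: the limit of > 50000 nM in this assay, at which 2 of the 4 values shown sit.

On these data alone, what a methoxy group or an amine would do on this same carbon stays open. So does whether the swap of hydroxy for hydrogen gives a similar result when a plain hydroxy stands in place of the (3-methylbut-2-en-1-yl)oxy group.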